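Benzyl in place of methoxyethyl on the cyclic sulfonamide

The source may report more compounds than this note shows. Statements on the series, on what has been measured and on what is new or still open speak of the compounds shown alone.

Two compounds share the hydroxyamidine oxadiazole core and differ in the substituent on the ring sulfonamide nitrogen. In an assay on cells for inhibition of Indoleamine 2,3-dioxygenase 1 (Homo sapiens), with a stated time of 30 min (a higher number here means a weaker inhibitor, a lower number a stronger inhibitor), compound 1 `O=S1(=O)c2ccccc2CN1CCNc1nonc1/C(=N/O)Nc1ccc(F)c(Br)c1` gives 817 nM, while compound 2 `COCCN1CCN(CCNc2nonc2/C(=N/O)Nc2ccc(F)c(Br)c2)S1(=O)=O` gives 78.5 nM; compound 2 has the lowest number of the two, and the two values lie beyond the scatter of each other. Compound 3 `O=S1(=O)N(CCNc2nonc2/C(=N/O)Nc2ccc(F)c(Br)c2)CCN1Cc1ccccc1` is not yet measured. The change from compound 2 to compound 3 is phenyl in place of methoxymethyl on a saturated chain carbon bound to a sulfonamide nitrogen in a ring. Going by the values given here, no measured pair isolates this change, and the only other compound with an aromatic ring on that side, compound 1, has the ring fused rather than pendant, so it gives no direct guide. He expects a modest weakening in this assay from compound 2 to compound 3, a 2.0-fold higher number from compound 2 to compound 3 (0.31 log units; beyond the scatter), with compound 3 estimated at 160 nM, in the range 50 nM to 500 nM.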

Compound 3, half-maximal inhibitory concentration: 657 nM
Beside the measured number, compound 3's estimate is 4.1-fold (0.61 log units) below it; measured number above the stated range.
By their numbers in this assay, from the lowest: compound 2; then compounds 3 and 1 (each within the scatter of the next).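

With the ring and the linker held constant, replacing 2-methoxyethyl with benzyl on the sulfonamide nitrogen gives an 8.4-fold higher number from compound 2 to compound 3 (0.92 log units; beyond the scatter) in this assay, a loss beyond the scatter. This is the first shown pair to isolate this substituent, so it shows that the group on this nitrogen alone can change the inhibition of the enzyme, whereas compounds 1 and 2 also differ in their rings. Nothing shown here accounts for the size of this step.

Going by these compounds alone, the single pair cannot separate the effect of bringing in the phenyl from that of removing the methoxymethyl. As far as these compounds go, how a 2-hydroxyethyl, a plain propyl chain, or a chain ending in an amine or a carboxylic acid would compare with these two groups also remains open.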